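Swapping one five-membered ring for another

The source may report more compounds than this note shows. Statements on the series, on what has been measured and on what is new or still open speak of the compounds shown alone.

- compound 1 `COc1cc(-c2cnn3cc(OC)c(C)nc23)ccn1` gives 13%
- compound 2 `COc1cnc2c(-c3ccnc(OC)c3)cnn2c1` gives 10%
- compound 3 `COc1cc(-c2cnn3cc(OC)c(C4CCCC4)nc23)ccn1` gives 7%

In an ADME assay on microsomes from liver (Rattus norvegicus) for metabolic stability, with a stated time of 60 min, tested at 1 uM (on this read-out higher numbers stand for a more stable compound and lower numbers for a less stable compound), the three compounds stay close together, and compound 3 lies within the scatter of both others. Three measured steps involve the aromatic carbon that changes next: a number 6 percentage points lower from compound 1 to compound 3 (within the scatter) and a number 3 percentage points lower from compound 2 to compound 3 (within the scatter) and a number 3 percentage points lower from compound 1 to compound 2 (within the scatter) all bear on it.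

Compound 4 `COc1cc(-c2cnn3cc(OC)c([C@H]4COC(C)(C)C4)nc23)ccn1` keeps the core of compound 3 but swaps the group on that carbon, and a group of 7 heavy atoms (6 carbon, 1 oxygen; one five-membered non-aromatic ring with 1 hetero atom) in place of a group of 5 heavy atoms (5 carbon; one five-membered non-aromatic ring of carbon only), on an aromatic carbon sums up the swap. Among the compounds with values here, no measured compound has a ring with a hetero atom at this place, so the data do not test this change directly. With a number 6 percentage points lower from compound 1 to compound 3 (within the scatter) as the guide, a step beyond the scatter is not expected here, although a surprise remains possible. The expected outcome in this assay is a number 5 percentage points higher from compound 3 to compound 4 (within the scatter) for this swap. The estimate for compound 4 is 12% with an expected range from 4% to 30% in this test.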

Compound 4, percent of the compound remaining: 30%
Estimate against measurement, compound 4: 18 percentage points below; the range from low to high includes it.
By their numbers in this assay, from the lowest: compounds 3, 2 and 1 (each within the scatter of the next); then compound 4.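

In this assay, this aromatic carbon turns out to be a place where the substituent can shift the number: hydrogen, methyl and cyclopentyl all stayed within the scatter of one another, whereas the new group gives a number 23 percentage points higher from compound 3 to compound 4 (beyond the scatter), a number 20 percentage points higher from compound 2 to compound 4 (beyond the scatter) and a number 17 percentage points higher from compound 1 to compound 4 (beyond the scatter). The step from cyclopentyl keeps a five-membered non-aromatic ring in place, so a change within that ring, not the mere presence of such a ring, goes with the higher number. No measurement shown here explains the rise.

As far as these compounds go, the ring oxygen, the methyl groups on the ring and the defined stereocentre all enter together, so their separate contributions stay unknown. Also open, from the compounds shown here alone, is what the mirror-image form would give, or a pyrrolidine ring, with nitrogen in place of the oxygen.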